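This account rests on a few compounds, and the source may have more. Where it says the series, first, only, none or still open, it means among the compounds named here.

Measured so far:
compound 1 `N#Cc1c(-c2ccc(Cl)cc2)cc(-c2ccc(Cl)cc2)n(C(=O)c2ccccc2)c1=O`: 3.75 ug/mL
compound 2 `N#Cc1c(-c2ccc(Cl)cc2)cc(-c2ccc(Cl)cc2)n(CC(O)CCl)c1=O`: 4.8 ug/mL

In a functional assay on HepG2 cells (Homo sapiens) for cytotoxicity, read by sulforhodamine B assay, with a stated time of 48 h (a lower number here means a stronger inhibitor, a higher number a weaker inhibitor), compound 1 gives 3.75 ug/mL and compound 2 gives 4.8 ug/mL. Among the measured compounds shown here, compound 2 sits alongside compound 1: the only measured step, a 1.3-fold higher number from compound 1 to compound 2 (0.11 log units; within the scatter), is within the scatter, so neither number is separated from the other.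

Compound 3 `N#Cc1c(-c2ccc(Cl)cc2)cc(-c2ccc(Cl)cc2)n(CC2CO2)c1=O` differs from compound 2 by oxiran-2-yl in place of 2-chloro-1-hydroxyethyl on a saturated chain carbon bound to an aromatic nitrogen. For the measured compounds named here, no measured step covers this change; the one step available, on the same aromatic nitrogen substituent, was within the scatter, and on that basis the expected step is a 1.1-fold lower number from compound 2 to compound 3 (0.03 log units; within the scatter), no direction beyond the scatter. For compound 3 the expected value in this assay is 4.5 ug/mL, range 2 ug/mL to 10 ug/mL.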

Compound 3, half-maximal inhibitory concentration: 6.2 ug/mL
Estimate against measurement, compound 3: 1.4-fold (0.14 log units) below, and the stated range covers the measured number.
By their numbers in this assay, from the lowest: compounds 1, 2 and 3 (each within the scatter of the next).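

With (oxiran-2-yl)methyl in place of 3-chloro-2-hydroxypropyl, this assay shows a 1.3-fold higher number from compound 2 to compound 3 (0.11 log units; within the scatter) for this substituent on the aromatic nitrogen, and with it in place of benzoyl, a 1.7-fold higher number from compound 1 to compound 3 (0.22 log units; within the scatter) as well. The position therefore carries a three-membered ring with 0 hydrogen-bond donors without any of the three compounds separating from the others, so the readout does not distinguish these substituents. Nothing available bears on the reason for this result.

Open, from the compounds shown here alone, is whether an amine, a carboxylic acid or a longer chain on this nitrogen would move the number beyond the scatter. Also open, going by these compounds, is whether the same holds with changes elsewhere on the shared core.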